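Chain Lengthening in Naphthamide Piperidines at the D4 Receptor

The source may hold more compounds than are shown below. What is called first, only, known or untested is meant among the compounds shown, and "the series" means these compounds.

Two measured naphthalene carboxamides share a piperidine that carries a phenyl-terminated saturated chain on its ring nitrogen. In an assay on isolated protein for displacement of a labelled ligand from D(4) dopamine receptor (Homo sapiens) (a lower number here means a stronger inhibitor, a higher number a weaker inhibitor), compound 1 `O=C(NC1CCN(CCCc2ccccc2)CC1)c1cccc2ccccc12` gives 71 nM. Compound 2 `O=C(NC1CCN(CCCc2ccccc2)CC1)c1ccc2ccccc2c1`, in which the amide is attached at the other position of the naphthalene, gives 63 nM in this assay. Compound 2 shows the lower of the two numbers, but the two values sit within the scatter of each other, so no order between them can be claimed.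

The unmeasured compound 3 `O=C(NC1CCN(CCCCc2ccccc2)CC1)c1ccc2ccccc2c1` keeps the naphthamide of compound 2 and differs only in the chain: benzyl in place of phenyl on a saturated chain carbon, three bonds along the chain from an amine nitrogen in a ring. Going by the values given here, no measured pair here shows what such a lengthening does in this assay, so the expectation rests on compound 2 alone. A step of modest size in either direction is plausible, and a change beyond the scatter cannot be ruled out. Compound 3 is expected to give 90 nM in this assay, with a likely range from 30 nM to 300 nM. This estimate means a step from compound 2 to compound 3 of a 1.4-fold higher number from compound 2 to compound 3 (0.15 log units; within the scatter).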

Compound 3, inhibition constant: 281 nM
Estimate against measurement, compound 3: 3.1-fold (0.49 log units) below; measured number inside the range.
By their numbers in this assay, from the lowest: compounds 2 and 1 (each within the scatter of the next); then compound 3.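

In this assay, benzyl in place of phenyl on a saturated chain carbon, three bonds along the chain from an amine nitrogen in a ring, brings a 4.5-fold higher number from compound 2 to compound 3 (0.65 log units; beyond the scatter) and so gives the first separation beyond the scatter among these compounds. The values of compound 1 at 71 nM and compound 2 at 63 nM had shown only that moving the amide attachment on the naphthalene leaves the two numbers within the scatter of each other, whereas this result shows that the number also responds to the length of the chain and that lengthening it here raises the number. The data shown offer no explanation for this step.

What the compounds shown leave open is whether the trend runs in one direction along the chain, since a shorter chain such as phenethyl or a still longer chain could either continue it or depart from it. As far as these compounds go, it also remains open whether the same lengthening has a similar effect with the amide attachment of compound 1, and whether an ether oxygen or a second amine within the chain would be tolerated at this place.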